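The source may report more compounds than this note shows. Statements on the series, on what has been measured and on what is new or still open speak of the compounds shown alone.

Measured in a functional assay on MCF7 cells (Homo sapiens) for antiproliferative activity, read by MTT assay, with a stated time of 48 h; on this read-out lower numbers stand for stronger inhibition and higher numbers for weaker inhibition:
- compound 1 `Cc1ccc(NCc2cn(-c3ccccc3)nc2-c2ccc(C)cc2)cc1`: 7260 nM
- compound 2 `Cc1ccc(-c2nn(-c3ccccc3)cc2CNc2ccc(F)cc2)cc1`: 5880 nM

With only these two values, compound 2 cannot be ordered against compound 1. The gap between them is a 1.2-fold lower number from compound 1 to compound 2 (0.09 log units; within the scatter).

Compound 3 `Cc1ccc(-c2nn(-c3ccccc3)cc2CNc2ccc(Br)cc2)cc1` follows from compound 2 by one exchange: bromo in place of fluoro on an aromatic carbon. In words, this is bromo in place of fluoro on an aromatic carbon, para to a large group. Going by the values given here, the one measured step that bears on it is a 1.2-fold lower number from compound 1 to compound 2 (0.09 log units; within the scatter), which is also an exchange of a single group on an aromatic carbon. Among the compounds with values here, no bromo compound has been measured, so this evidence is indirect and thin. In this assay, no shift beyond the scatter is expected, and no direction is favoured. The expected step is a 1.1-fold lower number from compound 2 to compound 3 (0.03 log units; within the scatter). For compound 3 the estimated value is 5500 nM, with an expected range of 2500 nM to 12000 nM.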

Compound 3, half-maximal inhibitory concentration: 6890 nM
Compound 3: the middle estimate sits 1.3-fold (0.10 log units) below what was measured, and the stated range covers the measured number.
By their numbers in this assay, from the lowest: compounds 2, 3 and 1 (each within the scatter of the next).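

In this assay, going from 4-fluorophenyl to 4-bromophenyl gives a small step (a 1.2-fold higher number from compound 2 to compound 3 (0.07 log units; within the scatter)), so this halogen exchange on an aromatic carbon, para to a large group, stays within the scatter. The comparison of bromo with methyl at the same place reads the same way (a 1.1-fold lower number from compound 1 to compound 3 (0.02 log units; within the scatter)), and methyl, fluoro and bromo therefore cannot be told apart here in this read-out. No data accompany these numbers that could explain why the three groups read alike.

As far as these compounds go, whether any group at this carbon moves the number beyond the scatter stays open, for example an amine, a carboxylic acid or a longer chain. Also open, from the compounds shown here alone, is how the read-out responds to changes elsewhere on the core of compound 1.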